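This account rests on a few compounds, and the source may have more. Where it says the series, first, only, none or still open, it means among the compounds named here.

Compound 1 `O=C1COc2ccc(-c3cccc(NS(=O)(=O)c4ccc(F)cc4)c3)cc2N1C1CC1` gives > 40000 nM in a functional assay on HepG2 cells (Homo sapiens) for antiproliferative activity, read by MTT assay, with a stated time of 72 h (a lower number here means a stronger inhibitor, a higher number a weaker inhibitor), a limit rather than a number.
Compound 2 `COc1ccc(N2C(=O)COc3ccc(-c4cnc5ccccc5c4)cc32)cc1` gives > 40000 nM in this assay, again a limit.
Compound 3 `COc1cccc(N2C(=O)COc3ccc(-c4cnc(Cl)c(NS(=O)(=O)c5ccc(F)cc5)c4)cc32)c1` gives > 40000 nM in this assay, also a limit.

Among the compounds with values here, compound 2 therefore stands where all three measured compounds stand, at the limit of > 40000 nM in this assay, at which 3 of the 3 values shown sit; no compound gives a number in this assay against which a change could be judged. Compound 4 `O=C1COc2ccc(-c3cnc4ccccc4c3)cc2N1` differs from compound 2 by hydrogen in place of 4-methoxyphenyl on an amide-type nitrogen in a ring. Within the data shown here, no step between measured compounds is available, so the expected movement in this assay is none beyond the scatter, in no particular direction. The step of a number no higher from compound 2 to compound 4 (the limit leaves the size open) is estimated to be flat. Compound 4 is estimated at 40000 nM, between 15000 nM and 100000 nM, most probably reported again as a limit in this assay.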

Compound 4, half-maximal inhibitory concentration: 26300 nM
Compound 4: the middle estimate sits 1.5-fold (0.18 log units) above what was measured; the range from low to high includes it.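

Within the data shown here, compound 4 is the first compound here to give a number rather than a limit in this assay, so the amide-type nitrogen needs no 4-methoxyphenyl for a value to be read. The change is an at least 1.5-fold lower number from compound 2 to compound 4 (0.18 log units; that floor lies within the scatter). Its true size stays open because the starting point is a limit, not a number: the limit of > 40000 nM in this assay, at which 3 of the 4 values shown sit.

Whether a methyl group or a longer chain on this nitrogen would give a number is left open. So is whether hydrogen there would do the same with other groups on the shared core.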